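From a primary amide to a cyclohexyl amide

The compounds below may be only part of what the source reports. "The series", "measured", "known", "first", "only" and "open" are said of these compounds alone.

Compound 1 `CC(C)C[C@H](NC(=O)[C@]1(Cc2ccccc2)CCN1C(=O)OCc1ccccc1)C(N)=O`: 100000 nM
Compound 2 `CC(C)[C@H](NC(=O)[C@]1(Cc2ccccc2)CCN1C(=O)OCc1ccccc1)C(N)=O`: > 100000 nM

In an ADME assay on HELF cells (Homo sapiens) for cytotoxicity, with a stated time of 3 days (a lower number here means that less compound is tolerated, a higher number that more compound is tolerated), compound 1 gives 100000 nM. For compound 2 the result is a limit of the assay, > 100000 nM, and no number beyond it is available. The step of a number no lower from compound 1 to compound 2 (the limit leaves the size open) therefore cannot be sized, which rests on (the limit of > 100000 nM in this assay, at which 1 of the 2 values shown sits). Compound 2 thus stands at the upper edge of what the assay reports.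

Compound 3 `C[C@H](NC(=O)[C@]1(Cc2ccccc2)CCN1C(=O)OCc1ccccc1)C(=O)NC1CCCCC1` differs from compound 2 by 1-(cyclohexylcarbamoyl)ethyl in place of 1-carbamoyl-2-methylpropyl on an amide-type nitrogen. Going by the values given here, the single measured step concerns a different part of the molecule and its size is open, so it gives no direction or size for this change. The value of compound 3 is therefore expected to sit near the edge again, estimated at 80000 nM. The range expected for compound 3 runs from 25000 nM to 100000 nM. The expected step of an at least 1.2-fold lower number from compound 2 to compound 3 (0.09 log units; that floor lies within the scatter) is estimated to stay within the scatter.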

Compound 3, minimum cytotoxic concentration: > 100000 nM
Compound 3 ended at the assay's limit; the forecaster's own chance of this, stated with the estimate: 45%; at least 1.2-fold (0.09 log units) between middle value and limit.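

In this assay compound 3 gives > 100000 nM, which is a limit of the assay. A 1-(cyclohexylcarbamoyl)ethyl group on the amide-type nitrogen, with its six-membered non-aromatic ring of carbon only, therefore does not bring the number down into the measurable range, something the two earlier compounds, which carry an unsubstituted carbamoyl group, could not show. The change gives a number no lower from compound 1 to compound 3 (the limit leaves the size open), and the other new step, which joins two limits, cannot be read: the limit of > 100000 nM in this assay, at which 2 of the 3 values shown sit.

Going by these compounds, how far the true values of compound 2 and compound 3 lie beyond the limit stays unknown, so the two cannot be ranked. On these data alone, whether an amine or a carboxylic acid in place of the cyclohexyl ring would give a measurable number also stays open.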